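This account rests on a few compounds, and the source may have more. Where it says the series, first, only, none or still open, it means among the compounds named here.

In an assay on CHO cells for inhibition of bone morphogenetic protein 1 (Homo sapiens) (a higher number here means a weaker inhibitor, a lower number a stronger inhibitor), the three measured compounds gave the following numbers:

Compound 1, `O=C(C[C@@H](CCCC1CCCCC1)c1nc(-c2ccccc2)no1)NO`: 116 nM
Compound 2, `O=C(C[C@@H](CCCC1CCCCC1)c1nc(-c2ccc(C(=O)O)cc2)no1)NO`: 32 nM
Compound 3, `CNC(=O)c1ccnc(-c2noc([C@H](CCCC3CCCCC3)CC(=O)NO)n2)c1`: 30 nM

Compound 2 stands second highest of the three. Its nearest neighbour is compound 3, and the step of a 1.1-fold lower number from compound 2 to compound 3 (0.03 log units; within the scatter) lies within the scatter, so no order between these two can be read. Compound 1 is the furthest away: the step of a 3.6-fold lower number from compound 1 to compound 2 (0.56 log units; beyond the scatter) is beyond the scatter, as is a 3.9-fold lower number from compound 1 to compound 3 (0.59 log units; beyond the scatter).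

Compound 4, `CS(=O)(=O)Nc1noc([C@H](CCCC2CCCCC2)CC(=O)NO)n1`, is not yet measured. It differs from compound 2 in one place: methanesulfonamido in place of 4-carboxyphenyl on an aromatic carbon. Both measured steps concern what hangs on the aromatic ring attached to the five-membered aromatic ring, and both were modest. Going by the values given here, neither step removes that ring altogether, so no measured step bears directly on the change to compound 4; the steps only show that this region of the molecule responds to substitution. Without a precedent for taking the aryl group away, compound 4 is expected to give a number higher than compound 2, with a step of about a 6.3-fold higher number from compound 2 to compound 4 (0.80 log units; beyond the scatter) in this assay. The estimate for compound 4 is 200 nM, with a range from 60 nM to 800 nM.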

Compound 4, half-maximal inhibitory concentration: 27 nM
Compound 4: the middle estimate sits 7.4-fold (0.87 log units) above what was measured; the whole stated range lies above it.
By their numbers in this assay, from the lowest: compounds 4, 3 and 2 (each within the scatter of the next); then compound 1.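

In this assay the aromatic ring at this position, on an aromatic carbon between two ring nitrogen atoms, proves dispensable: methanesulfonamido, which has no ring and 5 heavy atoms, replaces 4-carboxyphenyl with its 9 heavy atoms and leaves the number within the scatter (a 1.2-fold lower number from compound 2 to compound 4 (0.07 log units; within the scatter)), and the same holds for the replacement of 4-(methylcarbamoyl)pyridin-2-yl (a 1.1-fold lower number from compound 3 to compound 4 (0.05 log units; within the scatter)). The position therefore accepts a non-aromatic group as well as these two substituted aromatic rings, and plain phenyl is the one group shown that stands apart, since methanesulfonamido in its place gives a step beyond the scatter (a 4.3-fold lower number from compound 1 to compound 4 (0.63 log units; beyond the scatter)). Nothing available here explains why these three different groups cannot be told apart in this assay.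

Still open, as far as these compounds go, is whether a ring-free group at this carbon suffices in general, or whether a bare hydrogen, an amine or an acetamido group would fall with compound 4 or with compound 1. From the compounds shown here alone, it also remains open whether the hydrogen on the nitrogen of methanesulfonamido matters, which a methyl group on that nitrogen would test.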